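Methoxy for Chloro on the Sulfonyl Aryl Group

This account rests on a few compounds, and the source may have more. Where it says the series, first, only, none or still open, it means among the compounds named here.

Compound 1, `Cc1ccc(S(=O)(=O)c2cnc3cc(Cl)ccc3c2N2CCC(C)CC2)cc1C`: 86%
Compound 2, `COc1ccc(S(=O)(=O)c2cnc3cc(Cl)ccc3c2N2CCC(C)CC2)cc1OC`: 93%
Compound 3, `CC1CCN(c2c(S(=O)(=O)c3ccc(Cl)c(Cl)c3)cnc3cc(Cl)ccc23)CC1`: 89%

Of the compounds shown here, three sharing one core have been tested in an assay on isolated protein for displacement of a labelled ligand from metabotropic glutamate receptor 5 (Homo sapiens), with a stated time of 60 min, tested at 1 uM; a higher number here means more inhibition at the concentration tested (going by the name of the read-out), a lower number less inhibition. They differ only in the aryl group on the sulfonyl sulfur. Compound 3 stands second highest of the three; its closest neighbour is compound 1, while compound 2 lies furthest from it, and both gaps are within the scatter. The same holds for every measured step: a number 7 percentage points higher from compound 1 to compound 2 (within the scatter), a number 3 percentage points higher from compound 1 to compound 3 (within the scatter) and a number 4 percentage points lower from compound 2 to compound 3 (within the scatter) all fall inside the usual variation, so nothing here separates the three aryl groups.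

Compound 4, `COc1ccc(S(=O)(=O)c2cnc3cc(Cl)ccc3c2N2CCC(C)CC2)cc1Cl`, has not yet been measured. It differs from compound 3 by methoxy in place of chloro on an aromatic carbon, reading 3,4-dichlorophenyl to 3-chloro-4-methoxyphenyl. The step that bears most directly on it is a number 4 percentage points lower from compound 2 to compound 3 (within the scatter), where both methoxy groups were exchanged for chloro without a change beyond the scatter; the step of a number 7 percentage points higher from compound 1 to compound 2 (within the scatter) likewise shows methoxy groups in place of methyl groups leaving the number where it was. On that basis compound 4 is expected to show no step beyond the scatter, a number 1 percentage points higher from compound 3 to compound 4 (within the scatter). Compound 4 is therefore estimated at 90%, with a range from 82% to 96%.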

Compound 4, a percentage reported as inhibition, at one concentration (the size of the read-out at that concentration, not a potency): 93%
For compound 4 the middle estimate is 3 percentage points below the measured one, within the range that was stated.
By their numbers in this assay, from the lowest: compounds 1, 3, 2 and 4 (each within the scatter of the next).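

Going by these compounds alone, for the first time, the exchange is confined to a single group: one chloro gives way to methoxy on an aromatic carbon, ortho to a chloro group and para to a large group, with a number 4 percentage points higher from compound 3 to compound 4 (within the scatter) in this assay, so this place accepts the single methoxy without a step beyond the scatter, whereas the earlier comparison between the 3,4-dichlorophenyl and 3,4-dimethoxyphenyl groups changed two groups together. The mixed 3-chloro-4-methoxyphenyl group also cannot be told apart from either group it was compared with here, with no change at the digits printed from compound 2 to compound 4 (within the scatter) on the exchange of chloro for methoxy and a number 7 percentage points higher from compound 1 to compound 4 (within the scatter) against the 3,4-dimethylphenyl group, so four aryl groups now stand within the scatter of their listed neighbours. No measurement on hand explains why these groups read so much alike.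

From the compounds shown here alone, whether an amine, a carboxylic acid or a longer chain such as butoxy at this place would produce a step beyond the scatter remains open. A read-out at one concentration is also not a potency, so any differences in potency among these four compounds remain unresolved.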